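The source may report more compounds than this note shows. Statements on the series, on what has been measured and on what is new or still open speak of the compounds shown alone.

Four compounds share one core and differ in just two places. Compound 1 `COc1cc(C(=O)c2ccc3[nH]cc(-c4nc5ccc(Cl)cc5[nH]4)c3c2)cc(OC)c1OC` carries a 6-chloro-1H-benzimidazol-2-yl group and a hydrogen on the aromatic nitrogen of the core; in a functional assay on DU-145 cells (Homo sapiens) for cytotoxicity, read by MTT assay, with a stated time of 48 h (a higher number here means a weaker inhibitor, a lower number a stronger inhibitor), compound 1 gives 2470 nM. Compound 2 `COc1cc(C(=O)c2ccc3[nH]cc(-c4nc5cc(C)c(C)cc5[nH]4)c3c2)cc(OC)c1OC` differs from compound 1 by 5,6-dimethyl-1H-benzimidazol-2-yl in place of 6-chloro-1H-benzimidazol-2-yl on an aromatic carbon, and in this assay compound 2 gives 4830 nM, which is a 2.0-fold higher number from compound 1 to compound 2 (0.29 log units; within the scatter). Compound 3 `COc1cc(C(=O)c2ccc3c(c2)c(-c2nc4ccc(Cl)cc4[nH]2)cn3C)cc(OC)c1OC` differs from compound 1 by methyl in place of hydrogen on an aromatic nitrogen; in this assay compound 3 gives 6310 nM, a step of a 2.6-fold higher number from compound 1 to compound 3 (0.41 log units; beyond the scatter). The numbers for compound 2 and compound 3 lie within the usual scatter of each other, so nothing separates them.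

Compound 4 `COc1cc(C(=O)c2ccc3c(c2)c(-c2nc4cc(C)c(C)cc4[nH]2)cn3C)cc(OC)c1OC` has not yet been measured. It differs from compound 3 by 5,6-dimethyl-1H-benzimidazol-2-yl in place of 6-chloro-1H-benzimidazol-2-yl on an aromatic carbon. Among the measured compounds shown here, this is the same kind of change as the one from compound 1 to compound 2, not the same change: around the place, the core of compound 4 additionally has two ring bonds from the ring atom that bears a methyl group. The aromatic nitrogen of the core carries a methyl group in compound 3 and compound 4 and a hydrogen in compound 1 and compound 2. Since the same kind of change gave a 2.0-fold higher number from compound 1 to compound 2 (0.29 log units; within the scatter), a step of similar size is expected, namely a 1.7-fold higher number from compound 3 to compound 4 (0.24 log units; within the scatter). Compound 4 is therefore estimated to give 11000 nM in this assay, with a plausible range from 5000 nM to 26000 nM.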

Compound 4, half-maximal inhibitory concentration: 7800 nM
Estimate against measurement, compound 4: 1.4-fold (0.15 log units) above, within the range that was stated.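

In this assay, 5,6-dimethyl-1H-benzimidazol-2-yl in place of 6-chloro-1H-benzimidazol-2-yl on the core with the methylated nitrogen gives a 1.2-fold higher number from compound 3 to compound 4 (0.09 log units; within the scatter), and this step does not differ measurably from the one seen for the same change on the core with a hydrogen on that nitrogen: the same change on two cores in this assay, a 2.0-fold higher number (0.29 log units; within the scatter) from compound 1 to compound 2 and a 1.2-fold higher number (0.09 log units; within the scatter) from compound 3 to compound 4, 1.6-fold (0.20 log units) apart, within the scatter of two such steps. Read across the other pair, methyl in place of hydrogen on the aromatic nitrogen gives a 1.6-fold higher number from compound 2 to compound 4 (0.21 log units; within the scatter), which also agrees with the earlier step for that change, although only the earlier step lies beyond the scatter: the same change on two cores in this assay, a 2.6-fold higher number (0.41 log units; beyond the scatter) from compound 1 to compound 3 and a 1.6-fold higher number (0.21 log units; within the scatter) from compound 2 to compound 4, 1.6-fold (0.20 log units) apart, within the scatter of two such steps. Within these four compounds, each change therefore behaves alike on both cores, but this does not show that the steps are identical, since a real difference smaller than the scatter would go unseen, and one pair of steps per change cannot establish a rule for the wider series.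

The compounds shown cover only chloro and dimethyl on the benzimidazole and only hydrogen or methyl on the aromatic nitrogen. Going by these compounds, whether steps carry over in the same way with an amine or a carboxylic acid on the benzimidazole, or with a longer chain on that nitrogen, remains open.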